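A few compounds are considered here, and "the series" means these few. Any claim that something is new, unique, unknown or untested is made for them only; others in the source may bear on it.

Measured compounds:
compound 1, `CC1CCN(c2c(S(=O)(=O)c3ccc(F)c(Cl)c3)cnc3cc(Cl)ccc23)CC1`, 94%
compound 2, `Cc1ccc(S(=O)(=O)c2cnc3ccc(Cl)cc3c2N2CCC(C)CC2)cc1F`, 68%
compound 3, `CC1CCN(c2c(S(=O)(=O)c3cc(F)cc(F)c3)cnc3c(F)cccc23)CC1`, 9%

All three numbers come from an assay on isolated protein for displacement of a labelled ligand from metabotropic glutamate receptor 5 (Homo sapiens), with a stated time of 60 min, tested at 1 uM; a lower number here means less inhibition, a higher number more inhibition at the concentration tested (going by the name of the read-out). Compound 1 gives 94% and compound 2 gives 68%, both well above compound 3, which gives 9%. Compound 3 therefore stands lowest of the three; its gap to compound 2 is beyond the scatter, and its gap to compound 1 is wider still. For the measured compounds named here, none of these pairs differs in a single place, so no step is attributed to any one change; compound 3 differs from compound 1 both in the group on the sulfonyl sulfur and in the substitution of the shared core.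

Compound 4, `CC1CCN(c2c(S(=O)(=O)c3ccc(F)c(Cl)c3)cnc3c(F)cccc23)CC1`, is not yet measured in this assay. It differs from compound 3 in one place: 3-chloro-4-fluorophenyl in place of 3,5-difluorophenyl on a sulfonyl sulfur. The group that enters is the same group that sits on the sulfonyl sulfur of compound 1, while the core of compound 4 keeps the fluorine pattern of compound 3. Because compound 1 gives 94%, an increase beyond the scatter is expected, but how much of the low value of compound 3 belongs to its core and how much to the 3,5-difluorophenyl cannot be separated on the numbers shown. The step from compound 3 to compound 4 is estimated at a number 36 percentage points higher from compound 3 to compound 4 (beyond the scatter). Compound 4 is expected to give 45%, within 10% to 85%.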

Compound 4, a percentage reported as inhibition, at one concentration (the size of the read-out at that concentration, not a potency): 95%
The estimate for compound 4 lay 50 percentage points below the measured number; measured number above the stated range.
By their numbers in this assay, from the lowest: compound 3; then compound 2; then compounds 1 and 4 (each within the scatter of the next).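

With the core of compound 3 held fixed, 3-chloro-4-fluorophenyl in place of 3,5-difluorophenyl on a sulfonyl sulfur gives a number 86 percentage points higher from compound 3 to compound 4 (beyond the scatter) in this assay, a large step for an exchange that leaves the heavy-atom count of the group unchanged. For the compounds shown here, the low reading of compound 3 therefore goes with the 3,5-difluorophenyl on this core and not with the fluorine pattern of the core alone, as compound 4 gives 95% on that same core, a separation that the earlier compounds could not make. Nothing available here accounts for the size of this step.

Going by these compounds alone, only this one pair can be read, so it remains open whether the same exchange would have a similar effect on the core of compound 1 or of compound 2, and which of the two differences in the ring substitution carries the step. Also open, on these data alone, is how the series would respond on the sulfonyl sulfur to an unsubstituted phenyl, a 3-chlorophenyl, a 4-fluorophenyl or a saturated cyclohexyl group.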